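From 2-acetoxyethyl to 2-hydroxybutyl on the shared core

The source may hold more compounds than are shown below. What is called first, only, known or untested is meant among the compounds shown, and "the series" means these compounds.

Compound 1 `CC(C)=CC[C@@H](OC[C@H](C)O)C1=CC(=O)c2c(O)ccc(O)c2C1=O` gives 24500 nM here
Compound 2 `CCCCC(O)CC(=O)O[C@H](CC=C(C)C)C1=CC(=O)c2c(O)ccc(O)c2C1=O` gives 45300 nM here
Compound 3 `CC(=O)OCCO[C@H](CC=C(C)C)C1=CC(=O)c2c(O)ccc(O)c2C1=O` gives 15500 nM here

These values come from a functional assay on DU-145 cells (Homo sapiens) for cytotoxicity, read by MTT assay (on this read-out higher numbers stand for weaker inhibition and lower numbers for stronger inhibition), and the measured steps are a 1.6-fold lower number from compound 1 to compound 3 (0.20 log units; within the scatter) and a 2.9-fold lower number from compound 2 to compound 3 (0.47 log units; beyond the scatter) so compound 3 sits within the scatter of compound 1 and has a lower number than compound 2. The change to compound 4 `CCC(O)CO[C@H](CC=C(C)C)C1=CC(=O)c2c(O)ccc(O)c2C1=O` is 1-hydroxypropyl in place of acetoxymethyl on a saturated chain carbon bound to an oxygen on a saturated carbon and puts 2-hydroxybutyl where 2-acetoxyethyl stood. For the measured compounds named here, the closest precedent is the exchange of 1-hydroxyethyl and acetoxymethyl at this place, seen in a 1.6-fold lower number from compound 1 to compound 3 (0.20 log units; within the scatter) and staying within the scatter. Reversing that exchange, a slightly higher number but no step beyond the scatter is expected in this assay and the estimated step is a 1.5-fold higher number from compound 3 to compound 4 (0.17 log units; within the scatter) on that basis. For compound 4 the expected value is 23000 nM (estimated range 11000 nM to 46000 nM).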

Compound 4, half-maximal inhibitory concentration: 16400 nM
Compound 4: the middle estimate sits 1.4-fold (0.15 log units) above what was measured, within the range that was stated.
By their numbers in this assay, from the lowest: compounds 3, 4, 1 and 2 (each within the scatter of the next, the first and the last beyond it).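

In this assay, the exchange of acetoxymethyl for 1-hydroxypropyl gives a 1.1-fold higher number from compound 3 to compound 4 (0.02 log units; within the scatter), so the acetate ester is not required at this place, and lengthening 1-hydroxyethyl to 1-hydroxypropyl gives a 1.5-fold lower number from compound 1 to compound 4 (0.17 log units; within the scatter). Only the (2-hydroxyhexyl)carbonyl group stands apart from 2-hydroxybutyl, with a 2.8-fold lower number from compound 2 to compound 4 (0.44 log units; beyond the scatter). No available evidence accounts for these steps. From the compounds shown here alone, it remains open how an amine or a carboxylic acid at the end of this chain would read here, and whether a longer chain without the carbonyl, such as 2-hydroxyhexyl, would stay within the scatter of 2-hydroxybutyl.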